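Amine substituents on the adenosine series: compound 4

The source may hold more compounds than are shown below. What is called first, only, known or untested is meant among the compounds shown, and "the series" means these compounds.

Measured so far:
- compound 1 `Nc1ncnc2c1ncn2[C@@H]1O[C@H](CNC(=O)CC[C@H](N)C(=O)O)[C@@H](O)[C@H]1O`: no result reported in an assay for inhibition of tRNA (cytosine(38)-C(5))-methyltransferase (Homo sapiens), with a stated time of 5 min, tested at 100 uM; on this read-out lower numbers stand for less inhibition and higher numbers for more inhibition at the one concentration tested (going by the name of the read-out)
- compound 2 `CC(C)N(CC[C@H](N)C(=O)O)C[C@H]1O[C@@H](n2cnc3c(N)ncnc32)[C@H](O)[C@@H]1O`: 44%
- compound 3 `Nc1ncnc2c1ncn2[C@@H]1O[C@H](CN(CC[C@H](N)C(=O)O)CC2CCC2)[C@@H](O)[C@H]1O`: 32%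

Compound 2 holds the higher of the two numbers; compound 3 sits a number 12 percentage points lower from compound 2 to compound 3 (beyond the scatter), and compound 1 carries no number against which to place it.

Compound 4 `C#CCCN(CC[C@H](N)C(=O)O)C[C@H]1O[C@@H](n2cnc3c(N)ncnc32)[C@H](O)[C@@H]1O` is the next member. It differs from compound 2 in one place: but-3-yn-1-yl in place of isopropyl on an amine nitrogen. Both the change from compound 2 to compound 3 and this one exchange the isopropyl on the amine nitrogen for another group without rings or heteroatoms. For the measured compounds named here, the one measured step, a number 12 percentage points lower from compound 2 to compound 3 (beyond the scatter), is the sole guide; it went beyond the scatter, but only modestly. Going by the values given here, a group with no ring and one triple bond outside aromatic rings has no precedent, so the but-3-yn-1-yl case cannot be placed more precisely than that single step allows. The expectation for compound 4 is therefore a step of a number 6 percentage points lower from compound 2 to compound 4 (within the scatter), a small loss that may well stay within the scatter. Compound 4 is estimated at 38%, with a range from 22% to 54%.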

Compound 4, a percentage reported as inhibition, at one concentration (the size of the read-out at that concentration, not a potency): 30.2%
For compound 4 the middle estimate is 7.8 percentage points above the measured one; the measured number falls inside the stated range.
By their numbers in this assay, from the lowest: compounds 4 and 3 (each within the scatter of the next); then compound 2.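

In this assay, the exchange of isopropyl for but-3-yn-1-yl on the amine nitrogen gives a number 13.8 percentage points lower from compound 2 to compound 4 (beyond the scatter) and so adds a second replacement with a loss of modest size; among compounds 2, 3 and 4, isopropyl now holds the highest number, and neither of the other two goes against this. The ring-free but-3-yn-1-yl and the ring-bearing cyclobutylmethyl are not told apart, with a number 1.8 percentage points lower from compound 3 to compound 4 (within the scatter) as the printed step, so neither a ring nor a triple bond outside aromatic rings separates these two compounds on this read-out. Nothing at hand accounts for the loss at this nitrogen or for the match between these two groups.

Still open, going by these compounds, is whether a methyl, an ethyl or a longer saturated chain on the amine nitrogen would keep the number of compound 2 or fall with compounds 3 and 4. Also open, on these data alone, is how a substituent ending in an amine or a carboxylic acid would read at this position, since all three groups compared here carry no hydrogen-bond donors or acceptors.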